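The source may report more compounds than this note shows. Statements on the series, on what has been measured and on what is new or still open speak of the compounds shown alone.

Of the compounds shown here, three that share one core have been tested in a functional assay on HO8910 cells (Homo sapiens) for inhibition, read by MTT assay, with a stated time of 24 h, tested at 0.1 ug/mL; a lower number here means less inhibition of growth, a higher number more inhibition of growth at the concentration tested. In this assay compound 1 (`O=C(CCCCC1CCSS1)Nc1ccccc1Cl`) gives 8.17%, and compound 2 (`O=C(CCCCC1CCSS1)Nc1ccccn1`) gives 1.14%. These two readings lie within the usual scatter of each other, so they cannot be ranked. Compound 3 (`O=C(CCCCC1CCSS1)Nc1ccc(Cl)cn1`) is reported only as "not active" (no number reported). It therefore has no single number, and its place on the scale can be given only in those words. Both numbers that do exist are small for a test of growth inhibition.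

Compound 4 (`O=C(CCCCC1CCSS1)Nc1ccc(Br)cn1`) has not yet been measured. It differs from compound 3 in one place: bromo in place of chloro on an aromatic carbon. This puts bromo in place of chloro on an aromatic carbon, and the rest of the structure stays the same. Among the compounds with values here, no measured pair in this small set shows what such a swap does, so the size of the step cannot be read from the data. The expectation is therefore no step beyond the scatter, in either direction, starting from compound 3 at "not active" (no number reported). Another report without a number would not be surprising. The expected value for compound 4 is 3%, with an estimated range from 0% to 12%.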

Compound 4, percent growth inhibition at one concentration: "not active" (no number reported)
Compound 4: no number reported, and the estimate cannot be compared.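

Compound 3 and compound 4 are both reported in this assay without a number, so no step can be read for bromo in place of chloro. These compounds leave open whether that swap changes growth inhibition at all, and whether either compound would give a measurable reading under other conditions. No supporting evidence bears on this result.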